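Moving the ring nitrogen on the piperidine amide of compound 3

The source may report more compounds than this note shows. Statements on the series, on what has been measured and on what is new or still open speak of the compounds shown alone.

Of the compounds shown here, three have been measured in a physicochemical assay for lipophilicity, read by HPLC, measured as chromatographic lipophilicity, at pH 7.4; on this read-out lower numbers stand for lower lipophilicity and higher numbers for higher lipophilicity. Compound 1 `CC(C)(C)C(=O)N1N=CCC1c1cc(F)cc(F)c1` gives 6.3 in this assay, and compound 2 `Cc1ccc(C2CC=NN2C(=O)C(C)(C)C)cc1F` gives 6.6. Compound 3 `O=C(c1cccnc1)N1CCC(C(=O)N2N=CCC2c2ccccc2)CC1`, which carries a (pyridin-3-yl)carbonyl on its piperidine ring, gives 2.6 and stands lowest of the three; compound 1 is nearest to it, and compound 2 is furthest, both beyond the usual scatter.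

Compound 4 `O=C(c1ccccn1)N1CCC(C(=O)N2N=CCC2c2ccccc2)CC1` has not yet been measured. It differs from compound 3 in a single place (pyridin-2-yl in place of pyridin-3-yl on a carbonyl carbon); the two share every atom, and only the ring nitrogen of the pyridyl group has moved. Within the data shown here, the change keeps the count of acceptors and donors the same, and no measured pair in this set shows what this move does in this assay.

Compound 4 is therefore expected to remain close to compound 3, with a step of a number 0.30 log units higher from compound 3 to compound 4 (within the scatter) that is expected to be small and, if anything, slightly upward, but not clearly beyond the scatter. On that basis compound 4 is estimated at 2.9 in this assay, within a range from 2.4 to 3.4.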

Compound 4, distribution coefficient: 3.1
Beside the measured number, compound 4's estimate is 0.20 log units below it; the range from low to high includes it.
By their numbers in this assay, from the lowest: compound 3; then compound 4; then compounds 1 and 2 (each within the scatter of the next).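

The set now holds its first step between compounds that differ in one place: in this assay, pyridin-2-yl in place of pyridin-3-yl on a carbonyl carbon gives a number 0.50 log units higher from compound 3 to compound 4 (beyond the scatter) while the heavy atoms and the counts of donors and acceptors in the two groups stay the same. This shows that the read-out at this position can separate two pyridyl isomers, so the placement of the ring nitrogen alone is enough to give a step beyond the usual scatter, though only a modest one. The data offer no measurement that accounts for the step, so the result stands as an observation from a single pair and not as an explained trend.

What the compounds shown leave open is how pyridin-4-yl or a plain phenyl group on the same carbonyl carbon would read, and so whether the ring nitrogen gives a graded series of values at this position or only this one difference. Going by these compounds, it is also open whether the same exchange would give a step of similar size in a compound carrying a methoxy group or an amine on the pyridine ring, or on a different core.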